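This account rests on a few compounds, and the source may have more. Where it says the series, first, only, none or still open, it means among the compounds named here.

Measured so far in an assay on isolated protein for binding affinity to 5-hydroxytryptamine receptor 4 (Homo sapiens); on this read-out higher numbers stand for weaker inhibition and lower numbers for stronger inhibition:
compound 1, `Clc1ccccc1-c1n[nH]cc1N1CCNCC1`, > 10000 nM;
compound 2, `Clc1ccc(-c2n[nH]cc2N2CCNCC2)cc1`, > 10000 nM;
compound 3, `Fc1ccccc1-c1n[nH]cc1N1CCNCC1`, > 10000 nM.

Each of these values is a limit of this assay and not a number. The change from compound 1 to compound 3 is fluoro in place of chloro on an aromatic carbon, and its step that the two limits leave unreadable from compound 1 to compound 3 cannot be read because of the limit of > 10000 nM in this assay, at which 3 of the 3 values shown sit. The difference between the cores of compound 1 and compound 2 is not broken down here. Compound 4, `Fc1ccc(-c2n[nH]cc2N2CCNCC2)cc1`, awaits measurement; it differs from compound 2 by fluoro in place of chloro on an aromatic carbon. This is the same kind of change as that from compound 1 to compound 3, though the place differs: ortho to a large group there, para to a large group here. Compound 4 is expected to show a step that the limit leaves unreadable from compound 2 to compound 4 in this assay. That expectation rests on (the limit of > 10000 nM in this assay, at which 3 of the 3 values shown sit). Compound 4 is therefore estimated at 20000 nM.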

Compound 4, inhibition constant: > 10000 nM
Compound 4 was reported as a limit (the forecaster's own chance of this, stated with the estimate: 85%); the middle value is on the limit's open side.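

The step from compound 2 to compound 4 cannot be read, because both values are limits in this assay and not numbers: the limit of > 10000 nM in this assay, at which 4 of the 4 values shown sit. The compounds shown leave open how chloro and fluoro compare, and what affinity any of these compounds has.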